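Lengthening the Acid Chain on an Isoindolinone Amide Scaffold

This account rests on a few compounds, and the source may have more. Where it says the series, first, only, none or still open, it means among the compounds named here.

Measured so far:
compound 1 `O=C(O)CCN1Cc2ccc(NC(=O)c3ccc(C4CCNCC4)cc3)cc2C1=O`: 9600 nM
compound 2 `CC(CC(=O)O)N1Cc2ccc(NC(=O)c3ccc4c(c3)CNCC4)cc2C1=O`: 86 nM
compound 3 `O=C(O)CCN1Cc2ccc(NC(=O)c3ccc(N4CCNCC4)cc3)cc2C1=O`: 540 nM

In a functional assay on a cell-free system (Platelet, plasma, Homo sapiens) for inhibition (on this read-out lower numbers stand for stronger inhibition and higher numbers for weaker inhibition), compound 1 gives the highest number of the three, so it is the weakest inhibitor of this small set. Its nearest neighbour is compound 3, reached by an 18-fold lower number from compound 1 to compound 3 (1.25 log units; beyond the scatter), a change at the far end of the molecule. Going by the values given here, compound 2, which differs from compound 1 in two places at once, gives a still lower number, but no single step connects the two.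

Compound 4 `O=C(O)CCCN1Cc2ccc(NC(=O)c3ccc(C4CCNCC4)cc3)cc2C1=O` differs from compound 1 only on the acid-bearing chain: carboxymethyl in place of carboxy on a saturated chain carbon, two bonds along the chain from an amide-type nitrogen in a ring. Among the compounds with values here, none of the measured steps touches this chain, so nothing in the data tells how this assay responds to a longer chain, and the expectation must rest on compound 1 alone. The step from compound 1 is therefore expected to be a 1.0-fold higher number from compound 1 to compound 4 (0.02 log units; within the scatter), with a wide margin in either direction. Compound 4 is estimated at 10000 nM, with a range from 2500 nM to 40000 nM.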

Compound 4, half-maximal inhibitory concentration: 410000 nM
Estimate against measurement, compound 4: 41-fold (1.61 log units) below, outside the stated range (above it).
By their numbers in this assay, from the lowest: compound 2; then compound 3; then compound 1; then compound 4.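

In this assay, lengthening 2-carboxyethyl to 3-carboxypropyl gives a 43-fold higher number from compound 1 to compound 4 (1.63 log units; beyond the scatter) and so weakens inhibition sharply. Going by these compounds alone, this is the first measured step on the acid-bearing chain, and it shows that one added chain carbon, with the carboxylic acid itself kept, can matter as much at this end of the molecule as the large change at the far end, an 18-fold lower number from compound 1 to compound 3 (1.25 log units; beyond the scatter) in the same assay. Nothing measured here says why the longer chain costs so much.

Going by these compounds, whether the same lengthening would have a similar effect on compound 3, which carries piperazin-1-yl, remains open. So does how the assay would respond to carboxymethyl on the ring nitrogen, or to a still longer chain such as 4-carboxybutyl.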